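Swapping Ethoxy for Methyl on the Five-Membered Ring

The compounds below may be only part of what the source reports. "The series", "measured", "known", "first", "only" and "open" are said of these compounds alone.

Two close relatives have been measured so far. Compound 1 `COc1ccc(-c2nc(Nc3ccc(S(N)(=O)=O)cc3)n3nnnc3c2C#N)cc1OC` gives 39 nM in a functional assay on HeLa cells (Homo sapiens) for inhibition, read by sulforhodamine B assay, with a stated time of 48 h; a higher number here means a weaker inhibitor, a lower number a stronger inhibitor. Compound 2 `CCOC1=NN(c2nc(Nc3ccc(S(N)(=O)=O)cc3)nc(-c3ccc(OC)c(OC)c3)c2C#N)C(=O)C1` gives 42 nM in this assay, the highest of the two numbers; its nearest neighbour is compound 1, whose value differs by an amount that lies within the scatter, so the two cannot be told apart on this evidence. Compound 3 `COc1ccc(-c2nc(Nc3ccc(S(N)(=O)=O)cc3)nc(N3N=C(C)CC3=O)c2C#N)cc1OC` has not yet been measured. It differs from compound 2 by methyl in place of ethoxy on a carbon with a double bond to nitrogen. Within the data shown here, no measured pair shows the effect of this particular change, so nothing in the data points to a direction. The step of a 1.4-fold higher number from compound 2 to compound 3 (0.15 log units; within the scatter) is therefore expected to be small, likely within the scatter. Compound 3 is estimated at 60 nM, with a range from 20 nM to 180 nM in this assay.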

Compound 3, half-maximal inhibitory concentration: 46 nM
Estimate against measurement, compound 3: 1.3-fold (0.12 log units) above, and the stated range covers the measured number.
By their numbers in this assay, from the lowest: compounds 1, 2 and 3 (each within the scatter of the next).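

Among these compounds, replacing ethoxy with methyl on a carbon with a double bond to nitrogen gives the first direct reading at this position: in this assay the swap amounts to a 1.1-fold higher number from compound 2 to compound 3 (0.04 log units; within the scatter). The ethoxy group, with its oxygen, can therefore give way to methyl with no difference that this assay can resolve, so this pair gives no sign that the ethoxy oxygen matters here. No supporting measurement is available to explain this outcome.

Whether this carbon would tolerate an amine, a carboxylic acid or a longer chain such as butoxy remains open, since ethoxy and methyl are the only two groups shown there. Also open, on these data alone, is whether the same swap would give a similar result on the core of compound 1 or in cells other than those of this assay.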